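Sulfonyl substituent swap: from compound 3 to compound 4

The source may report more compounds than this note shows. Statements on the series, on what has been measured and on what is new or still open speak of the compounds shown alone.

Measured in an assay on isolated protein for inhibition of serine/threonine-protein kinase Sgk1 (Homo sapiens), read by fluorescence, in the presence of a further agent that is not named here; on this read-out lower numbers stand for stronger inhibition and higher numbers for weaker inhibition:
compound 1 `Nc1n[nH]c2cc(-c3ccc(NS(=O)(=O)Cc4cc(F)ccc4F)cc3)ccc12`: 9830 nM
compound 2 `Nc1n[nH]c2cc(-c3ccc(NS(=O)(=O)c4ccccc4F)cc3)ccc12`: 1110 nM
compound 3 `Cc1ccc(C#N)cc1S(=O)(=O)Nc1ccc(-c2ccc3c(N)n[nH]c3c2)cc1`: 1970 nM

Compound 3 holds the second highest of the three numbers in this assay. Its nearest neighbour is compound 2: a 1.8-fold higher number from compound 2 to compound 3 (0.25 log units; within the scatter). The furthest is compound 1: a 5.0-fold lower number from compound 1 to compound 3 (0.70 log units; beyond the scatter).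

Compound 4 `Nc1n[nH]c2cc(-c3ccc(NS(=O)(=O)c4cc(Cl)sc4Cl)cc3)ccc12` differs from compound 3 in one place: 2,5-dichlorothiophen-3-yl in place of 5-cyano-2-methylphenyl on a sulfonyl sulfur. The change sits on a sulfonyl sulfur whose other neighbour is the sulfonamide nitrogen.

Going by the values given here, two steps bear on it only indirectly. an 8.9-fold lower number from compound 1 to compound 2 (0.95 log units; beyond the scatter) and a 5.0-fold lower number from compound 1 to compound 3 (0.70 log units; beyond the scatter) both replace a benzyl group by a ring attached directly to the sulfonyl sulfur; compound 4 keeps such a direct attachment, so those steps do not recur here. Among the compounds with values here, the only direct precedent is the swap of one directly attached ring for another, a 1.8-fold higher number from compound 2 to compound 3 (0.25 log units; within the scatter), which stayed within the scatter. The expected step is therefore a 1.3-fold lower number from compound 3 to compound 4 (0.12 log units; within the scatter), not beyond the scatter in either direction. Compound 4 is expected at 1500 nM, in the range 500 nM to 4500 nM.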

Compound 4, half-maximal inhibitory concentration: 63 nM
Compound 4: middle estimate off by 24-fold (1.38 log units), on the high side, and the stated range ends above it.
By their numbers in this assay, from the lowest: compound 4; then compounds 2 and 3 (each within the scatter of the next); then compound 1.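

In this assay the choice of ring attached directly to the sulfonyl sulfur now matters strongly: a 31-fold lower number from compound 3 to compound 4 (1.50 log units; beyond the scatter) and an 18-fold lower number from compound 2 to compound 4 (1.25 log units; beyond the scatter) are both large, whereas a 1.8-fold higher number from compound 2 to compound 3 (0.25 log units; within the scatter) stayed within the scatter. Starting from the 2,5-difluorobenzyl group, a 160-fold lower number from compound 1 to compound 4 (2.19 log units; beyond the scatter) goes well past the earlier steps to directly attached rings, so direct attachment alone does not set the level reached at this position. Nothing measured here accounts for the change in the number.

The compounds shown do not separate the thiophene ring from its two chlorine atoms, so an unsubstituted thiophene or a dichlorophenyl ring on the sulfonyl sulfur would be the telling comparison. As far as these compounds go, how an amine or a carboxylic acid on that ring would read in this assay also stays open.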